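Swapping a pyridine for a thiophene on the shared core

The compounds below may be only part of what the source reports. "The series", "measured", "known", "first", "only" and "open" are said of these compounds alone.

Of the compounds shown here, three built on the same core have been measured in a functional assay for inhibition, with Homo sapiens as the target; on this read-out lower numbers stand for stronger inhibition and higher numbers for weaker inhibition. Compound 1 `COc1cccc(Nc2nccc(-c3ccsc3)n2)c1` gives 1800 nM. Compound 2 `Cc1cccc(Nc2nccc(-c3ccccn3)n2)c1` gives 700 nM. Compound 3 `CN(C)c1cccc(Nc2nccc(-c3ccccn3)n2)c1` gives 400 nM. For the measured compounds named here, compound 2 thus stands second highest of the three numbers: its nearest neighbour is compound 3, and the only step recorded between compounds that differ in one place, a 1.8-fold lower number from compound 2 to compound 3 (0.24 log units; within the scatter), lies within the scatter, while compound 1 sits further away, beyond the scatter.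

Compound 4 `Cc1cccc(Nc2nccc(-c3ccsc3)n2)c1` has not yet been measured in this assay. It differs from compound 2 in one place: thiophen-3-yl in place of pyridin-2-yl on an aromatic carbon.

Going by the values given here, no measured step touches this change. Among the compounds with values here, the one recorded step, from compound 2 to compound 3, concerns the other end of the molecule and is within the scatter, so it says nothing about the pyridine-to-thiophene swap. Compound 1 carries the same thiophen-3-yl group as compound 4 but also a different group at the other end, so its higher number against compound 2 can only hint that the thiophene side may run weaker. On that thin basis a modest rise is expected, a 2.0-fold higher number from compound 2 to compound 4 (0.30 log units; within the scatter), and compound 4 is estimated at 1400 nM, with a range from 450 nM to 4500 nM.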

Compound 4, half-maximal inhibitory concentration: 3800 nM
For compound 4 the middle estimate is 2.7-fold (0.43 log units) below the measured one, and the stated range covers the measured number.
By their numbers in this assay, from the lowest: compounds 3 and 2 (each within the scatter of the next); then compound 1; then compound 4.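

The swap now has a direct reading at this position, on the aromatic carbon next to the ring nitrogen: with the methyl group held constant, this assay gives a 5.4-fold higher number from compound 2 to compound 4 (0.73 log units; beyond the scatter) and so shows weaker inhibition with thiophen-3-yl than with pyridin-2-yl, a step beyond the scatter. The other end of the molecule also counts once thiophen-3-yl is fixed, since methyl in place of methoxy gives a 2.1-fold higher number from compound 1 to compound 4 (0.32 log units; beyond the scatter) and this smaller step also lies beyond the scatter, towards weaker inhibition. Nothing available here explains why either change weakens inhibition.

These compounds leave open whether the drop belongs to thiophen-3-yl itself or to the loss of pyridin-2-yl, a question that a plain phenyl ring or pyridin-3-yl at the same place could help to separate. They also leave open whether the swap would cost as much with dimethylamino at the other end, as carried by compound 3, or whether its size depends on the group held there.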